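The source may report more compounds than this note shows. Statements on the series, on what has been measured and on what is new or still open speak of the compounds shown alone.

Going by the values given here, in a functional assay on MDA-MB-231 cells (Homo sapiens) for inhibition, read by MTT assay, with a stated time of 48 h (on this read-out lower numbers stand for stronger inhibition and higher numbers for weaker inhibition), compound 2 `NS(=O)(=O)c1cc(C(=O)Nc2ccc(C(F)(F)F)cc2)ccc1Cl` gives 7320 nM, the higher of the two numbers so far and beyond the usual scatter from compound 1 `CC(C)(C)OC(=O)c1ccc(NC(=O)c2cccc(S(N)(=O)=O)c2)cc1`, which gives 700 nM. Compound 3 `CC(C)(C)OC(=O)c1ccc(NC(=O)c2ccc(Cl)c(S(N)(=O)=O)c2)cc1` has tert-butoxycarbonyl in place of trifluoromethyl on an aromatic carbon, para to a large group: tert-butoxycarbonyl in place of trifluoromethyl on an aromatic carbon. Compound 1 also carries tert-butoxycarbonyl and gives 700 nM, so compound 3 is expected to show stronger inhibition, with a lower number beyond the scatter. The expected change is a 6.7-fold lower number from compound 2 to compound 3 (0.82 log units; beyond the scatter). The estimated value for compound 3 is 1100 nM, within a range of 300 nM to 4000 nM.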

Compound 3, half-maximal inhibitory concentration in the MDA-MB-231 assay: 610 nM
Compound 3: the middle estimate sits 1.8-fold (0.26 log units) above what was measured, and the stated range covers the measured number.
By their numbers in the MDA-MB-231 assay, from the lowest: compounds 3 and 1 (each within the scatter of the next); then compound 2.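

In the MDA-MB-231 assay, tert-butoxycarbonyl in place of trifluoromethyl on this aromatic carbon gives a 12-fold lower number from compound 2 to compound 3 (1.08 log units; beyond the scatter), so inhibition here depends strongly on which of these two groups the position carries. Chloro in place of hydrogen on an aromatic carbon gives a 1.1-fold lower number from compound 1 to compound 3 (0.06 log units; within the scatter), so that change has no readable effect in this pair. In a physicochemical assay for lipophilicity (on this read-out higher numbers stand for higher lipophilicity and lower numbers for lower lipophilicity), compound 2 gives 2.76 and compound 3 gives 1.83. The stronger inhibition of compound 3 does not come with higher lipophilicity: the measured partition coefficient of compound 2, 2.76, and of compound 3, 1.83, a number 0.93 log units lower (beyond the scatter)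

As far as these compounds go, it remains open whether the whole tert-butoxycarbonyl group matters or only part of it. A carboxylic acid or a methyl ester on this carbon would help to separate the two.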